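Trading a methoxy for a hydroxy on a pyrazole-urea series

A few compounds are considered here, and "the series" means these few. Any claim that something is new, unique, unknown or untested is made for them only; others in the source may bear on it.

Of the compounds shown here, two have a number so far. In a functional assay on LOX IMVI cells (Homo sapiens) for inhibition, read by sulforhodamine B assay, with a stated time of 48 h (on this read-out lower numbers stand for stronger inhibition of growth and higher numbers for weaker inhibition of growth), compound 2 `COc1cc(-c2nn(-c3cccc(NC(=O)Nc4ccc(Cl)c(Cl)c4)c3)cc2-c2ccncc2)ccc1Cl` gives 954 nM, the lowest of the two numbers, while compound 1 `O=C(Nc1cccc(-n2cc(-c3ccncc3)c(-c3ccc(Cl)c(O)c3)n2)c1)Nc1cccc(C(F)(F)F)c1` gives 2530 nM in this assay, a gap that lies beyond the usual scatter. Compound 3 `O=C(Nc1cccc(-n2cc(-c3ccncc3)c(-c3ccc(Cl)c(O)c3)n2)c1)Nc1ccc(Cl)c(Cl)c1` has not yet been measured. It differs from compound 2 in one place: hydrogen in place of methyl on an oxygen on an aromatic ring, so the 4-chloro-3-methoxyphenyl group becomes a 4-chloro-3-hydroxyphenyl group. Among the compounds with values here, no measured pair differs only in this way, so the direction of the step is open. Compound 1 carries the same hydroxy group, but also a different urea end, so its weaker number cannot be pinned on the hydroxy alone. The expected step from compound 2 to compound 3 is a 1.6-fold higher number from compound 2 to compound 3 (0.20 log units; within the scatter), a modest weakening that may not exceed the scatter. Compound 3 is therefore estimated at 1500 nM in this assay, within a range from 500 nM to 4500 nM.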

Compound 3, concentration for 50% growth inhibition: 939 nM
Beside the measured number, compound 3's estimate is 1.6-fold (0.20 log units) above it; the range from low to high includes it.
By their numbers in this assay, from the lowest: compounds 3 and 2 (each within the scatter of the next); then compound 1.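

Removing the methyl from the oxygen on the aromatic ring leaves no readable change in this assay (a 1.0-fold lower number from compound 2 to compound 3 (0.01 log units; within the scatter)), so here methoxy and hydroxy cannot be told apart. With the hydroxy now held constant in both compounds, the change at the urea end, 3,4-dichlorophenyl in place of 3-(trifluoromethyl)phenyl, does give a step beyond the scatter (a 2.7-fold lower number from compound 1 to compound 3 (0.43 log units; beyond the scatter)), which places the earlier gap with that end of the molecule rather than with the hydroxy. Nothing available explains either result.

Going by these compounds, whether a larger group on that oxygen, such as an ethyl or a longer chain, would also leave the number in place remains open. So does whether methoxy and hydroxy would still match with the 3-(trifluoromethyl)phenyl group at the urea end.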